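Phenethyl in Place of Cyclopentyl on the Amine Chain

This account rests on a few compounds, and the source may have more. Where it says the series, first, only, none or still open, it means among the compounds named here.

Of the compounds shown here, two sharing one core have been measured in an assay on HEK293 cells for binding affinity to Gonadotropin-releasing hormone receptor (Homo sapiens), read by radioligand binding; a lower number here means a stronger inhibitor, a higher number a weaker inhibitor. Compound 1 `COc1cccc(-c2c(C)n(Cc3c(F)cccc3F)c(=O)n(C[C@H](C)NCc3ccccc3)c2=O)c1F` gives 51 nM. Compound 2 `COc1cccc(-c2c(C)n(Cc3c(F)cccc3F)c(=O)n(C[C@@H](N)C3CCCC3)c2=O)c1F` gives 94 nM, the highest of the two numbers; its nearest neighbour is compound 1, and the step of a 1.8-fold higher number from compound 1 to compound 2 (0.27 log units; within the scatter) lies within the scatter, so the two values cannot be ordered. Compound 3 `COc1cccc(-c2c(C)n(Cc3c(F)cccc3F)c(=O)n(C[C@@H](N)CCc3ccccc3)c2=O)c1F` has not yet been measured. It differs from compound 2 by phenethyl in place of cyclopentyl on a saturated chain carbon bound to an amine nitrogen and a saturated chain carbon. Within the data shown here, the only measured step that bears on this change is a 1.8-fold higher number from compound 1 to compound 2 (0.27 log units; within the scatter), which exchanged one side chain for another without any shift beyond the scatter; compound 3 now returns an aromatic ring to this part of the molecule, carried on a longer chain. Among the measured compounds shown here, with a single step of this size as the only guide, the expected step of a 1.2-fold lower number from compound 2 to compound 3 (0.07 log units; within the scatter) is not beyond the scatter in either direction. Compound 3 is therefore estimated at 80 nM in this assay, with a range from 30 nM to 250 nM.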

Compound 3, inhibition constant: 965 nM
Compound 3: the middle estimate sits 12-fold (1.08 log units) below what was measured, outside the stated range (above it).
By their numbers in this assay, from the lowest: compounds 1 and 2 (each within the scatter of the next); then compound 3.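

In this assay, among these compounds, the saturated chain carbon bound to an amine nitrogen and a saturated chain carbon proves far less tolerant than the earlier pair suggested: replacing cyclopentyl with phenethyl gives a 10-fold higher number from compound 2 to compound 3 (1.01 log units; beyond the scatter), a large step where the only earlier step lay within the scatter. An aromatic ring in this side chain is not in itself what separates the compounds, as compound 1 also carries one, in its benzylamino group, and the change to 1-amino-3-phenylpropyl still gives a 19-fold higher number from compound 1 to compound 3 (1.28 log units; beyond the scatter). How the ring is carried therefore matters here, and nothing presented offers an explanation for the size of these steps.

Phenethyl differs from cyclopentyl in both its ring and its length, so the compounds shown do not tell these two changes apart; a benzyl or phenyl group on the same carbon would bear on the chain length, and a cyclohexyl or 2-cyclopentylethyl group on the ring. On these data alone, it also remains open whether a benzylamino group in place of the free amine would change the number for the phenethyl side chain.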